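Compound 1 to compound 4: hydroxy to methoxy

The source may hold more compounds than are shown below. What is called first, only, known or untested is meant among the compounds shown, and "the series" means these compounds.

Measured in a functional assay on Bel-7402 cells (Homo sapiens) for antiproliferative activity, read by MTT assay, with a stated time of 72 h; on this read-out higher numbers stand for weaker inhibition and lower numbers for stronger inhibition:
compound 1 `COc1ccc(Cn2c(C(=O)O)c(CNCc3cccc(O)c3)c3ccccc32)cc1` gives > 50000 nM (a limit, not a number)
compound 2 `COc1cccc(CNCc2c(C(=O)O)n(Cc3ccc(C)cc3)c3cc(C)ccc23)c1` gives 5670 nM
compound 3 `COc1cccc(CNCc2c(C(=O)O)n(Cc3ccc(C)cc3)c3cc(C(C)C)ccc23)c1` gives 5920 nM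

Compound 1 has no number in this assay, only the limit of > 50000 nM in this assay, at which 1 of the 3 values shown sits (a limit of the assay). The change from compound 1 to compound 4 `COc1ccc(Cn2c(C(=O)O)c(CNCc3cccc(OC)c3)c3ccccc32)cc1` is hydroxy to methoxy on the 3-hydroxybenzyl group, counted as methyl in place of hydrogen on an oxygen on an aromatic ring with methyl in place of hydrogen on an oxygen on an aromatic ring. Among the compounds with values here, the only measured step (a 1.0-fold higher number from compound 2 to compound 3 (0.02 log units; within the scatter)) exchanges methyl for isopropyl on an aromatic carbon and gives no size for this change. The nearest guide is indirect: compound 2 (5670 nM) and compound 3 (5920 nM) both carry the 3-methoxybenzyl group, but both also differ from compound 4 in other places. A step toward stronger inhibition is therefore expected, though smaller than those values alone would suggest (an at least 3.3-fold lower number from compound 1 to compound 4 (0.52 log units; beyond the scatter)). Compound 4 is estimated at 15000 nM (expected range 5000 nM to 50000 nM).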

Compound 4, half-maximal inhibitory concentration: 52900 nM
Compound 4: the middle estimate sits 3.5-fold (0.55 log units) below what was measured; the whole stated range lies below it.
By their numbers in this assay, from the lowest: compounds 2 and 3 (each within the scatter of the next); then compound 4.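

In this assay no step can be read from compound 1 to compound 4, because compound 1 has only a limit of the assay and not a number: the limit of > 50000 nM in this assay, at which 1 of the 4 values shown sits.

The compounds shown leave open how large the change from 3-hydroxybenzyl to 3-methoxybenzyl is on the shared core.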